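Swapping the amide amine on a chlorophenyl ketoamide

The source may report more compounds than this note shows. Statements on the series, on what has been measured and on what is new or still open speak of the compounds shown alone.

Compound 1 `CCNC(=O)C(=O)CCc1ccc(Cl)cc1` gives 7940 nM in an assay on HEK-293T cells for inhibition of phospholipase A and acyltransferase 3 (Homo sapiens), with stated times of 30 min and 20 min; on this read-out higher numbers stand for weaker inhibition and lower numbers for stronger inhibition.
Compound 2 `CN(C)C(=O)C(=O)CCc1ccc(Cl)cc1` gives only a limit, > 10000 nM, in this assay.

Compound 2 thus stands at the limit of > 10000 nM in this assay, at which 1 of the 2 values shown sits, so only a floor is known for it. Compound 3 `O=C(CCc1ccc(Cl)cc1)C(=O)N1CCOCC1` differs from it by morpholin-4-yl in place of dimethylamino on a carbonyl carbon. Within the data shown here, the one measured step at that carbonyl carbon, an at least 1.2-fold higher number from compound 1 to compound 2 (0.10 log units; that floor lies within the scatter), lies within the scatter, so a swap of the amine there gives no clear shift. Compound 3 is therefore expected near 15000 nM, between 6000 nM and 50000 nM, most likely reported again as a limit. That would be an expected step that the limit leaves unreadable from compound 2 to compound 3.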

Compound 3, half-maximal inhibitory concentration: > 10000 nM
Compound 3 ended at the assay's limit; the forecaster's own chance of this, stated with the estimate: 65%; the middle value is on the limit's open side.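

Swapping ethylamino for morpholin-4-yl on the carbonyl carbon gives an at least 1.2-fold higher number from compound 1 to compound 3 (0.10 log units; that floor lies within the scatter), so this change has only a floor. The step from compound 2 to compound 3 cannot be read, since both values are limits. A ring carrying an oxygen therefore lands in the same place as dimethylamino, and a second amine joins the compounds without a number: the limit of > 10000 nM in this assay, at which 2 of the 3 values shown sit.

On these data alone, whether any amine here can give clearly stronger inhibition than compound 1 stays open. Methylamino, a longer chain such as butylamino, or piperidin-1-yl, the ring without the oxygen, could show how far the ethylamino result extends.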